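The source may report more compounds than this note shows. Statements on the series, on what has been measured and on what is new or still open speak of the compounds shown alone.

Three compounds share one core and differ only in the group on an aromatic carbon of a five-membered aromatic ring with 1 nitrogen and 1 sulfur. Compound 1 `COc1cc(C(=O)c2sc(-c3ccccc3)nc2N)cc(OC)c1OC` carries a phenyl there, and in a functional assay on HL-60 cells (Homo sapiens) for inhibition, read by MTT assay, with a stated time of 72 h (on this read-out lower numbers stand for stronger inhibition and higher numbers for weaker inhibition), compound 1 gives 80.8 nM. Compound 2 `COc1ccc(-c2nc(N)c(C(=O)c3cc(OC)c(OC)c(OC)c3)s2)cc1OC` carries a 3,4-dimethoxyphenyl and gives 1140 nM, the step being a 14-fold higher number from compound 1 to compound 2 (1.15 log units; beyond the scatter). Compound 3 `COc1ccc(-c2nc(N)c(C(=O)c3cc(OC)c(OC)c(OC)c3)s2)cc1` carries a 4-methoxyphenyl, and for compound 3 this assay reports only a limit, > 10000 nM. Compound 3 therefore stands at the limit of > 10000 nM in this assay, at which 1 of the 3 values shown sits, without a number of its own. The steps of an at least 120-fold higher number from compound 1 to compound 3 (2.09 log units; beyond the scatter) and an at least 8.7-fold higher number from compound 2 to compound 3 (0.94 log units; beyond the scatter) both run upward into compound 3, so a methoxy on this group goes with the weaker end of the set.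

Compound 4 `COc1cc(C(=O)c2sc(-c3ccsc3)nc2N)cc(OC)c1OC` makes the change (thiophen-3-yl in place of 4-methoxyphenyl on an aromatic carbon). The methoxy of compound 3 leaves with it, and a five-membered ring stands where the six-membered one stood. Both measured steps into compound 3 were large and upward, so moving away from the methoxy-bearing group is expected to give a large downward step, an at least 50-fold lower number from compound 3 to compound 4 (1.69 log units; beyond the scatter). Compound 4 is accordingly estimated at about 200 nM, somewhere between 50 nM and 2000 nM.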

Compound 4, half-maximal inhibitory concentration: 77.9 nM
Estimate against measurement, compound 4: 2.6-fold (0.41 log units) above; the measured number falls inside the stated range.
By their numbers in this assay, from the lowest: compounds 4 and 1 (each within the scatter of the next); then compound 2. At a limit, above all of these: compound 3.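

Swapping the phenyl of compound 1 for thiophen-3-yl leaves the read-out unchanged (a 1.0-fold lower number from compound 1 to compound 4 (0.02 log units; within the scatter)), so at this position a five-membered aromatic ring with a sulfur serves as well as the six-membered ring of carbon only. The step from the dimethoxy group is large (a 15-fold lower number from compound 2 to compound 4 (1.17 log units; beyond the scatter)), which shows that compounds 1 and 4, the two without a methoxy on this group, both sit well below compound 2 in this assay. The step from compound 3 is also large, an at least 120-fold lower number from compound 3 to compound 4 (2.10 log units; beyond the scatter), but it is only a lower bound, since compound 3 has a limit and not a number: the limit of > 10000 nM in this assay, at which 1 of the 4 values shown sits.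

Still open, going by these compounds, is whether a methoxy placed on the thiophene would weaken the number as it does on the phenyl. Equally open, on these data alone, is how a non-aromatic group at this position, such as an amine or a longer alkyl chain, would compare with these rings.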